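Urea-linked indolylthio series: aryl swap on the urea nitrogen

A few compounds are considered here, and "the series" means these few. Any claim that something is new, unique, unknown or untested is made for them only; others in the source may bear on it.

Measured compounds:
compound 1 `COc1ccc(NC(=O)Nc2nc(Sc3c[nH]c4ccccc34)cc(N3CCCCC3)n2)cc1`, 17400 nM
compound 2 `COc1ccc(NC(=O)Nc2nc(Nc3cc(OC)cc(OC)c3)cc(Sc3c[nH]c4ccccc34)n2)cc1`, 15100 nM
compound 3 `O=C(Nc1ccc(Cl)cc1)Nc1nc(Sc2c[nH]c3ccccc23)cc(N2CCCC2)n1`, 10400 nM

All three numbers come from a functional assay on PC-3 cells (Homo sapiens) for inhibition, with a stated time of 72 h; on this read-out lower numbers stand for stronger inhibition and higher numbers for weaker inhibition. Compound 1 carries the highest of the three numbers in this assay, but its nearest neighbour compound 2 differs by only a 1.2-fold lower number from compound 1 to compound 2 (0.06 log units; within the scatter), and compound 3 sits within the scatter of compound 1 as well, so no ordering among the three can be read from the data.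

Compound 4 `Cc1ccc(C)c(NC(=O)Nc2nc(Sc3c[nH]c4ccccc34)cc(N3CCCCC3)n2)c1` is not yet measured. Compared with compound 1 the change is 2,5-dimethylphenyl in place of 4-methoxyphenyl on an amide-type nitrogen. Among the compounds with values here, the one step that is known, from compound 1 to compound 2, alters the group on the aromatic carbon of the shared core and not the group on the amide-type nitrogen, so it does not speak to this change; compound 3, which carries a different aryl on the urea and a different amine, differs from compound 1 in two places and gives no clean step. Within the data shown here, no measured step bears on the aryl swap on the urea nitrogen, and all three known values lie within the scatter of one another.

Among the measured compounds shown here, the expectation for compound 4 is therefore no step beyond the scatter, that is a 1.2-fold lower number from compound 1 to compound 4 (0.06 log units; within the scatter), with the range kept wide because the site of the change has no precedent in this assay. The estimate for compound 4 is 15000 nM, between 5000 nM and 45000 nM.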

Compound 4, half-maximal inhibitory concentration: > 50000 nM
Compound 4 ended at the assay's limit; the forecaster's own chance of this, stated with the estimate: 10%; at least 3.3-fold (0.52 log units) between middle value and limit.
By their numbers in this assay, from the lowest: compounds 3, 2 and 1 (each within the scatter of the next). At a limit, above all of these: compound 4.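

In this assay, 2,5-dimethylphenyl in place of 4-methoxyphenyl on an amide-type nitrogen gives an at least 2.8-fold higher number from compound 1 to compound 4 (0.45 log units; beyond the scatter), the only step in the series shown that lies beyond the scatter. Compound 4 gives > 50000 nM, which is a limit of the assay and the only such reading among the compounds shown: the limit of > 50000 nM in this assay, at which 1 of the 4 values shown sits. By contrast, (3,5-dimethoxyphenyl)amino in place of piperidin-1-yl on an aromatic carbon gives a 1.2-fold lower number from compound 1 to compound 2 (0.06 log units; within the scatter), so among the single changes shown, only the aryl on the urea nitrogen moves the number beyond the scatter.

The swap removes a methoxy group and brings in two methyl groups at once, so the compounds shown cannot tell whether the loss of the methoxy group, the arrival of the methyl groups or both go with the step. Also open, as far as these compounds go, is how an aryl on the urea nitrogen carrying a single methyl group, an amine or a carboxylic acid would read on the core of compound 1, and therefore how far this position tolerates change.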